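The compounds below may be only part of what the source reports. "The series", "measured", "known", "first", "only" and "open" are said of these compounds alone.

Measured in an ADME assay on Vero cells (Chlorocebus sabaeus) for cytotoxicity, read by MTT assay, with a stated time of 96 h; on this read-out higher numbers stand for lower toxicity in this test and lower numbers for higher toxicity in this test:
- compound 1 `COc1cc(NCc2ccc(C)s2)ccc1-c1cnco1`: 24700 nM
- compound 2 `COc1cc(NCc2cncs2)ccc1-c1cnco1`: 232000 nM

Going by the values given here, of these two, compound 2 holds the higher number, and compound 1 is its only neighbour. The next compound, compound 3 `COc1cc(NCc2ccsc2)ccc1-c1cnco1`, keeps the shared core and alters one group: thiophen-3-yl in place of 1,3-thiazol-5-yl on a saturated chain carbon bound to a nitrogen on an aromatic ring. In words, thiophen-3-yl stands in place of 1,3-thiazol-5-yl on a saturated chain carbon bound to a nitrogen on an aromatic ring.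

Among the compounds with values here, one measured step bears on this change: a 9.4-fold higher number from compound 1 to compound 2 (0.97 log units; beyond the scatter). That step put 1,3-thiazol-5-yl in place of 5-methylthiophen-2-yl at the same place, so the change to compound 3 runs roughly back along it. Within the data shown here, the match is only partial, since thiophen-3-yl is not 5-methylthiophen-2-yl, and no measured compound shows what that difference is worth. A lower number is therefore expected in this assay, by a somewhat smaller margin than the measured step, though still beyond the scatter. The expected step is a 5.2-fold lower number from compound 2 to compound 3 (0.71 log units; beyond the scatter). For compound 3 the estimated value is 45000 nM, with an expected range from 15000 nM to 130000 nM.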

Compound 3, half-maximal cytotoxic concentration: 181000 nM
Compound 3: middle estimate off by 4.0-fold (0.60 log units), on the low side; measured number above the stated range.
By their numbers in this assay, from the lowest: compound 1; then compounds 3 and 2 (each within the scatter of the next).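

In this assay, the exchange at this place, on a saturated chain carbon bound to a nitrogen on an aromatic ring, gives a 1.3-fold lower number from compound 2 to compound 3 (0.11 log units; within the scatter) and so does not separate thiophen-3-yl from 1,3-thiazol-5-yl, although the two rings differ in their hetero atoms. The other new comparison, a 7.3-fold higher number from compound 1 to compound 3 (0.86 log units; beyond the scatter), shows that a ring with sulfur as its only hetero atom can also stand well apart from compound 1, so the earlier gap does not depend on the ring nitrogen of 1,3-thiazol-5-yl and compound 1 alone stands out among the three. Nothing available explains why 5-methylthiophen-2-yl stands apart in this way.

Since 5-methylthiophen-2-yl and thiophen-3-yl differ both in the methyl group and in the ring position of attachment, the compounds shown cannot divide the step between these two features, which a plain thiophen-2-yl group could help to settle. On these data alone, whether a six-membered ring such as phenyl or pyridinyl at this place would fall with compound 1 or with compounds 2 and 3 also remains open.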